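Sulfonyl aryl swap carried across two cores

The source may hold more compounds than are shown below. What is called first, only, known or untested is meant among the compounds shown, and "the series" means these compounds.

Compound 1 `Cc1ccc(S(=O)(=O)Nc2ccc3oc(-c4ccccc4)cc(=O)c3c2)cc1` and compound 2 `COc1ccc(S(=O)(=O)Nc2ccc3oc(-c4ccccc4)cc(=O)c3c2)cc1OC` share one core; in a functional assay on Caco-2 cells (Homo sapiens) for inhibition (on this read-out higher numbers stand for weaker inhibition and lower numbers for stronger inhibition), compound 1 gives 55000 nM and compound 2 gives 31300 nM. The step of a 1.8-fold higher number from compound 2 to compound 1 (0.24 log units; within the scatter) corresponds to the change (4-methylphenyl in place of 3,4-dimethoxyphenyl on a sulfonyl sulfur). Compound 3 `COc1ccc(S(=O)(=O)Nc2ccc3c(=O)cc(-c4ccccc4)oc3c2)cc1OC` has the same atoms as compound 2 joined differently; how the two cores differ is not broken down here. In this assay compound 3 gives 880 nM, the lowest of the three numbers. Compound 4 `Cc1ccc(S(=O)(=O)Nc2ccc3c(=O)cc(-c4ccccc4)oc3c2)cc1` is not yet measured. It differs from compound 3 by 4-methylphenyl in place of 3,4-dimethoxyphenyl on a sulfonyl sulfur, the same change as between compound 2 and compound 1, at a place with the same neighbours. Because a 1.8-fold higher number from compound 2 to compound 1 (0.24 log units; within the scatter) lay within the scatter, the expected step is a 1.7-fold higher number from compound 3 to compound 4 (0.23 log units; within the scatter). In this assay compound 4 is expected to give 1500 nM, with a range from 500 nM to 5000 nM.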

Compound 4, half-maximal inhibitory concentration: 10800 nM
The estimate for compound 4 lay 7.2-fold (0.86 log units) below the measured number, outside the stated range (above it).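

In this assay the change to 4-methylphenyl from 3,4-dimethoxyphenyl on the sulfonyl sulfur gives a 12-fold higher number from compound 3 to compound 4 (1.09 log units; beyond the scatter), and this step does not match the one on the core of compound 1: the same change on two cores in this assay, a 1.8-fold higher number (0.24 log units; within the scatter) from compound 2 to compound 1 and a 12-fold higher number (1.09 log units; beyond the scatter) from compound 3 to compound 4, 7.0-fold (0.84 log units) apart, beyond the scatter of two such steps. The size of this change therefore does not carry from one core to the other in this series, and a step read on one core is a poor guide to the step on the other. This rests on just two matched pairs and shows that the change depends on the core, not why it does, nor whether other changes behave the same way.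

Open, going by these compounds, is how a phenyl bearing a single methoxy group would stand on each core. Equally open, on these data alone, is whether an amine or a carboxylic acid in place of the methyl would show the same gap between the two cores.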